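This account rests on a few compounds, and the source may have more. Where it says the series, first, only, none or still open, it means among the compounds named here.

Values in a functional assay on MCF7 cells (Homo sapiens) for antiproliferative activity; a lower number here means a stronger inhibitor, a higher number a weaker inhibitor:
- compound 1 `CC(C)=CCCC1=CC[C@H](C(=O)Nc2ccc(O)cc2)[C@@H](c2ccccc2)C1`: 66700 nM
- compound 2 `COC(=O)CCNC(=O)[C@H]1CC=C(CCC=C(C)C)C[C@@H]1c1ccccc1`: 96800 nM
- compound 3 `CC(C)=CCCC1=CC[C@H](C(=O)NO)[C@@H](c2ccccc2)C1`: 72300 nM

Compound 3 stands level with the other two measured compounds, with a 1.1-fold higher number from compound 1 to compound 3 (0.04 log units; within the scatter) and a 1.3-fold lower number from compound 2 to compound 3 (0.13 log units; within the scatter). The next compound, compound 4 `CC(C)=CCCC1=CC[C@H](C(=O)O)[C@@H](c2ccccc2)C1`, differs from it by hydroxy in place of hydroxyamino on a carbonyl carbon. In words, this is hydroxy in place of hydroxyamino on a carbonyl carbon, so hydroxycarbamoyl becomes carboxy.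

Among the compounds with values here, no measured compound carries the carboxy group. The nearest evidence is the set of changes on the amide-type nitrogen, and the remaining one of these is a 1.5-fold higher number from compound 1 to compound 2 (0.16 log units; within the scatter). All three steps are small, although the groups exchanged differ widely. None of them removes that nitrogen, however, so they bear on this change only indirectly. In this assay, no step beyond the scatter is therefore expected, and the data favour neither direction. The expected step is a 1.0-fold higher number from compound 3 to compound 4 (0.02 log units; within the scatter). The value of compound 4 is estimated at 75000 nM, with an expected range from 35000 nM to 150000 nM.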

Compound 4, half-maximal inhibitory concentration: 64300 nM
Beside the measured number, compound 4's estimate is 1.2-fold (0.07 log units) above it; low and high end bracket the measured number.
By their numbers in this assay, from the lowest: compounds 4, 1, 3 and 2 (each within the scatter of the next).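

Compound 4 is the first of these compounds to lack the amide-type nitrogen, leaving only a hydroxy on the carbonyl carbon, and in this assay this removal gives a step within the scatter against each of the three nitrogen-bearing compounds: a 1.1-fold lower number from compound 3 to compound 4 (0.05 log units; within the scatter), a 1.5-fold lower number from compound 2 to compound 4 (0.18 log units; within the scatter) and a 1.0-fold lower number from compound 1 to compound 4 (0.02 log units; within the scatter). The earlier compounds shown here varied only the group on that nitrogen, whereas these steps show that, in this series, neither the nitrogen nor any group on it is needed to hold the number at this level. No available evidence explains this insensitivity.

On these data alone, it remains open whether anything at this position can move the number beyond the scatter, for example an amine or a hydroxymethyl group in place of the carboxy group. The compounds also leave untested whether changes elsewhere on the shared core would do so.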